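Isopropoxy to propoxy on the more tolerated compound

The source may report more compounds than this note shows. Statements on the series, on what has been measured and on what is new or still open speak of the compounds shown alone.

Within the data shown here, in a toxicity assay on Huh-7.5 cells (Homo sapiens) for inhibition, read by MTT assay, with a stated time of 96 h (a higher number here means that more compound is tolerated, a lower number that less compound is tolerated), two compounds have numbers so far. Compound 1 (`CC(C)Oc1ccc(C(=O)Nc2ccc(N(C)C)cc2)cc1NC(=O)C(C)Br`) gives 7900 nM. Compound 2 (`CCC(=O)Nc1cc(C(=O)Nc2ccc(OC)cc2)ccc1OC(C)C`) gives 113000 nM, the higher of the two numbers, and its gap to compound 1 lies beyond the usual scatter. These two compounds differ in more than one place, so their gap cannot be assigned to any single change.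

Compound 3 (`CCCOc1ccc(C(=O)Nc2ccc(OC)cc2)cc1NC(=O)CC`) is compound 2 with propyl in place of isopropyl on an oxygen on an aromatic ring. The two have the same atoms, joined differently. Among the measured compounds shown here, the series holds no measured step between compounds that differ in one place, so no measurement speaks directly to this change. On this limited basis, no step beyond the scatter is expected in this assay, and no direction is favoured. The estimated step is a 1.1-fold lower number from compound 2 to compound 3 (0.05 log units; within the scatter), expected to stay within the usual scatter. For compound 3 the estimated value is 100000 nM, with an expected range from 40000 nM to 220000 nM.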

Compound 3, half-maximal cytotoxic concentration: 106000 nM
Compound 3: middle estimate off by 1.1-fold (0.03 log units), on the low side; the range from low to high includes it.
By their numbers in this assay, from the lowest: compound 1; then compounds 3 and 2 (each within the scatter of the next).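

In this assay, among these compounds, propyl in place of isopropyl on an oxygen on an aromatic ring gives a 1.1-fold lower number from compound 2 to compound 3 (0.03 log units; within the scatter), the first step that isolates a single place. With the rest of compound 2 held constant, isopropoxy and propoxy therefore cannot be told apart in this assay, so joining these same atoms differently at this position leaves no readable difference in the tolerated concentration; the gap between compound 1 and compound 2 could not show this, as those two differ in more than one place. No measurement on hand bears on why this pair reads alike.

This single pair says nothing about how far the insensitivity extends on that oxygen, so a longer chain such as hexyl, or a chain ending in an amine or a carboxylic acid, remains an open test of whether the number holds. The gap between compound 1 and the other two also remains unassigned, and whether the same exchange would read alike on the core of compound 1 is open as well.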